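Working notes: furan to cyanophenyl on the shared core

The source may report more compounds than this note shows. Statements on the series, on what has been measured and on what is new or still open speak of the compounds shown alone.

Compound 1 `COc1ccc(Cc2cc(-c3cccs3)nn(CC(=O)Nc3ccc(Br)cc3)c2=O)cc1` sits at the limit of an assay on HL-60 cells for agonist activity at N-formyl peptide receptor 3 (Homo sapiens), read by calcium flux (a lower number here means that less compound is needed, a higher number that more compound is needed for the effect), where compound 1 gives > 50000 nM. Compound 2 `COc1ccc(-c2cc(Cc3cccc(OC)c3)c(=O)n(CC(=O)Nc3ccc(F)cc3)n2)cc1` also reaches only a limit, compound 2 giving > 50000 nM in this assay. Compound 3 `Cc1cc(Cc2ccoc2)c(=O)n(CC(=O)Nc2ccc(Br)cc2)n1` stands with them: in this assay compound 3 gives > 50000 nM, a limit rather than a number. No order among these three can be read, since all sit at the same limit, as the limit of > 50000 nM in this assay, at which 3 of the 3 values shown sit, records. Compound 4 `Cc1cc(Cc2ccc(C#N)cc2)c(=O)n(CC(=O)Nc2ccc(Br)cc2)n1` differs from compound 3 by 4-cyanophenyl in place of furan-3-yl on a saturated chain carbon bound to an aromatic carbon. For the measured compounds named here, no measured step shows what this change does. The expected step is none beyond the scatter, a number no higher from compound 3 to compound 4 (the limit leaves the size open). Compound 4 is estimated at 50000 nM, with a range from 10000 nM to 250000 nM, and is most likely to be reported again only as a limit.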

Compound 4, half-maximal effective concentration: > 50000 nM
Compound 4: no number, only a limit; the forecaster's own chance of this, stated with the estimate: 75%; the middle value lies on the limit itself.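

For the compounds shown here, compound 3 and compound 4 both stand only at a limit in this assay and no step between them can be read. The compounds shown leave open which change on the shared core, if any, gives a measurable number.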